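This account rests on a few compounds, and the source may have more. Where it says the series, first, only, none or still open, it means among the compounds named here.

The account follows a single change at the end of this series. In a functional assay on the whole organism (strain CF-1) for inhibition, with Mus musculus as the target (on this read-out lower numbers stand for an effect already at smaller amounts and higher numbers for an effect only at larger amounts of compound), compound 3 `Cc1nnc(CN2CCCC2)n1-c1ccc(Cl)cc1C(=O)c1ccccc1` gives 0.4 mg/kg and stands with the lowest number among the compounds that have a single value; its nearest neighbour is compound 2 `Cc1nnc(CN2CCCC2)n1-c1ccc(Cl)cc1C(=O)c1ccccc1Cl`, which in this assay gives 1.3 mg/kg, so that a 3.3-fold lower number from compound 2 to compound 3 (0.51 log units; beyond the scatter). Compound 1 `Cc1nnc(CN2CCCC2)n1-c1ccc(Cl)cc1C(O)c1ccccc1` has no single number; in this assay compound 1 gives 8 mg/kg; 32 mg/kg (2 entries), both entries far above those of compound 2 and compound 3.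

Compound 4 `Cc1nnc(CN2CCCC2)n1-c1ccc(Cl)cc1Cc1ccccc1` is not yet measured. It differs from compound 3 in that (benzyl in place of benzoyl on an aromatic carbon). Among the compounds with values here, no measured step covers this exact change. Within the data shown here, the only measured step concerns a chloro group and is modest. The values of compound 1 show that a compound lacking the benzoyl group but carrying a hydroxylated carbon in its place sits far from compound 3, and the several entries of compound 1 in this assay, 8 mg/kg; 32 mg/kg (2 entries) gives the spread of those entries. An increase in the number beyond the scatter is therefore expected, with the estimated step of a 13-fold higher number from compound 3 to compound 4 (1.10 log units; beyond the scatter). Compound 4 is expected to give about 5 mg/kg in this assay, with a range from 1.2 mg/kg to 25 mg/kg.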

Compound 4, dose for half-maximal effect: 36 mg/kg
Compound 4: middle estimate off by 7.2-fold (0.86 log units), on the low side, outside the stated range (above it).
By their numbers in this assay, from the lowest: compound 3; then compound 2; then compound 4.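

In this assay the exchange of benzoyl for benzyl gives a 90-fold higher number from compound 3 to compound 4 (1.95 log units; beyond the scatter), a large step that far exceeds the modest 3.3-fold lower number from compound 2 to compound 3 (0.51 log units; beyond the scatter), so this position responds much more strongly to losing the carbonyl than to losing the chloro group. The loss is just as clear when measured from the chlorinated ketone, with a 28-fold higher number from compound 2 to compound 4 (1.44 log units; beyond the scatter). Compound 4, at 36 mg/kg, thus joins compound 1 in lying far from both ketones, and the carbon bearing a hydroxyl offers no clear rescue, judging by its values: the several entries of compound 1 in this assay, 8 mg/kg; 32 mg/kg (2 entries)

The compounds shown leave open whether a linking group other than the carbonyl, such as a sulfonyl, an ether oxygen or an amine, could take its place. They also leave open how a fluoro or a methoxy group on the phenyl ring of the benzoyl group would behave.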